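The compounds below may be only part of what the source reports. "The series", "measured", "known", "first", "only" and "open" are said of these compounds alone.

Compound 3 `Cc1ccnc(-c2cnc(C(=O)CCCCCCc3ccccc3)o2)c1` gives the lowest number of the three compounds measured in an assay (Rattus norvegicus) for inhibition of Fatty-acid amide hydrolase 1 (Homo sapiens) (a lower number here means a stronger inhibitor, a higher number a weaker inhibitor), with compound 3 at 0.6 nM. Compound 1 `NC(=O)c1cccc(-c2cnc(C(=O)CCCCCCc3ccccc3)o2)c1` gives 6 nM in this assay, and compound 2 `COc1ccc(-c2cnc(C(=O)CCCCCCc3ccccc3)o2)cc1` gives 100 nM in this assay. The measured steps are a 10-fold lower number from compound 1 to compound 3 (1.00 log units; beyond the scatter), a 170-fold lower number from compound 2 to compound 3 (2.22 log units; beyond the scatter) and a 17-fold higher number from compound 1 to compound 2 (1.22 log units; beyond the scatter); each of them exchanges one aromatic ring for another on the same carbon of the shared core.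

Compound 4 `O=C(CCCCCCc1ccccc1)c1ncc(C(=O)C(F)(F)F)o1` differs from compound 3 in a single place: (trifluoromethyl)carbonyl in place of 4-methylpyridin-2-yl on an aromatic carbon. Among the compounds with values here, no measured step bears directly on this change, since every step recorded swaps one six-membered aromatic ring for another, whereas here the ring leaves altogether and a (trifluoromethyl)carbonyl enters. What the steps do show is that this position is sensitive: changing the group there moved the number in this assay across a wide span, as seen in the step of a 170-fold lower number from compound 2 to compound 3 (2.22 log units; beyond the scatter). On that basis compound 4 is expected to give a higher number than compound 3, by a step estimated as a 50-fold higher number from compound 3 to compound 4 (1.70 log units; beyond the scatter), though the direction rests on no directly comparable case. The estimate for compound 4 in this assay is 30 nM, with a range from 3 nM to 300 nM.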

Compound 4, inhibition constant: 4 nM
Beside the measured number, compound 4's estimate is 7.5-fold (0.88 log units) above it; the range from low to high includes it.
By their numbers in this assay, from the lowest: compound 3; then compounds 4 and 1 (each within the scatter of the next); then compound 2.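

In this assay this position does not depend on an aromatic ring: the ringless (trifluoromethyl)carbonyl on the aromatic carbon next to the ring oxygen gives a 6.7-fold higher number from compound 3 to compound 4 (0.82 log units; beyond the scatter) in a modest step, while a 25-fold lower number from compound 2 to compound 4 (1.40 log units; beyond the scatter) is a large step the other way. Among the groups seen so far, the ring-bearing 4-methylpyridin-2-yl remains ahead of the ringless group, yet the ringless group also clearly outdoes 4-methoxyphenyl, so the presence of a ring at this place does not by itself set the order. The remaining comparison, a 1.5-fold lower number from compound 1 to compound 4 (0.18 log units; within the scatter) within the scatter, leaves (trifluoromethyl)carbonyl and 3-carbamoylphenyl indistinguishable at this position. No measurement offered here accounts for any of these differences.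

The compounds shown leave open whether other ringless groups at this place, such as a nitrile, a carboxylic acid or a methyl ester, would fall near compound 4 or move well away from it. They also leave open whether the order of these groups would hold with a longer chain on the ketone of the shared core.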